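A few compounds are considered here, and "the series" means these few. Any claim that something is new, unique, unknown or untested is made for them only; others in the source may bear on it.

Measured so far:
- Compound 1 `COc1cc(OC)c(C(=O)/C=C/c2ccccc2Cl)c(O)c1CN1CCCC1`: 6900 nM
- Compound 2 `COc1cc(OC)c(C(=O)/C=C/c2ccccc2Cl)c(O)c1CN1CCCCC1`: 2500 nM

Both compounds were tested in a functional assay on ECa-109 cells (Homo sapiens) for antiproliferative activity, with a stated time of 72 h; a higher number here means a weaker inhibitor, a lower number a stronger inhibitor. Compound 2 has the lower of the two numbers, so it is the stronger inhibitor of this pair. The next compound, compound 3 `COc1cc(OC)c(C(=O)/C=C/c2ccccc2Cl)c(O)c1CN(C)C`, keeps the shared core and changes one group: dimethylamino in place of piperidin-1-yl on a saturated chain carbon bound to an aromatic carbon. In words, this puts dimethylamino in place of piperidin-1-yl on a saturated chain carbon bound to an aromatic carbon.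

Within the data shown here, only one measured step bears on this change, and it was made at the same place: a 2.8-fold lower number from compound 1 to compound 2 (0.44 log units; beyond the scatter). This modest step shows that this assay responds to the group there, and pyrrolidin-1-yl, in compound 1, gave the higher number. Among the measured compounds shown here, no compound without a ring at this place has been measured, so the step is only a loose guide. A modest rise in the number is therefore expected, towards the value of compound 1, which is 6900 nM. The estimated change is a 2.4-fold higher number from compound 2 to compound 3 (0.38 log units; beyond the scatter). For compound 3 the expected value is 6000 nM, with an estimated range of 2500 nM to 14000 nM.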

Compound 3, half-maximal inhibitory concentration: 2600 nM
The estimate for compound 3 lay 2.3-fold (0.36 log units) above the measured number; measured number inside the range.
By their numbers in this assay, from the lowest: compounds 2 and 3 (each within the scatter of the next); then compound 1.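

In this assay the open dimethylamino group does as well as the piperidin-1-yl ring, with a 1.0-fold higher number from compound 2 to compound 3 (0.02 log units; within the scatter), so a ring on this saturated chain carbon is not needed for activity at this level, even though dimethylamino brings only 3 heavy atoms where piperidin-1-yl brings 6. Against the pyrrolidin-1-yl group the same open group gives a 2.7-fold lower number from compound 1 to compound 3 (0.42 log units; beyond the scatter), which means compound 1 now stands apart from both compound 2 and compound 3, and the earlier step can no longer be read as a move from a favoured ring to an unfavoured group of any kind. No measurement here explains why pyrrolidin-1-yl alone gives the higher number.

As far as these compounds go, three groups at one position cannot show a general rule, so it remains open whether a morpholin-4-yl ring, a diethylamino group or a plain primary amine in this place would fall with compound 2 and compound 3 or with compound 1. From the compounds shown here alone, it is also open whether the same ordering would hold with a different group in place of the chlorine on the shared core.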